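A few compounds are considered here, and "the series" means these few. Any claim that something is new, unique, unknown or untested is made for them only; others in the source may bear on it.

Measured compounds in a functional assay on the whole organism with Mus musculus as the target, in the rotarod test; a lower number here means that less compound is needed, a higher number that more compound is needed for the effect:
- compound 1, `CN(C(=O)CNC(=O)CN)c1ccc(Cl)cc1C(=O)c1ccccc1Cl`: 27.7 mg/kg
- compound 2, `CCCCCC(=O)NCC(=O)N(C)c1ccc(Cl)cc1C(=O)c1ccccc1Cl`: 90 mg/kg
- compound 3, `CN(C(=O)CNC(=O)CN1CCN(c2ccccc2)CC1)c1ccc(Cl)cc1C(=O)c1ccccc1Cl`: a limit of the measurement, > 100 mg/kg

Compound 2 holds the higher of the two plain numbers; the step of a 3.2-fold higher number from compound 1 to compound 2 (0.51 log units; beyond the scatter) separates it from compound 1. Compound 3 gives only a limit (the limit of > 100 mg/kg in this assay, at which 1 of the 3 values shown sits), and the step of an at least 1.1-fold higher number from compound 2 to compound 3 (0.04 log units; that floor lies within the scatter) has a floor that says little. Compound 4, `CCCCCCCCCCCCCCCC(=O)NCC(=O)N(C)c1ccc(Cl)cc1C(=O)c1ccccc1Cl`, differs from compound 2 by decyl in place of hydrogen on a saturated chain carbon, five bonds along the chain from a carbonyl carbon. Growing the chain from amino to butyl already raised the number in a 3.2-fold higher number from compound 1 to compound 2 (0.51 log units; beyond the scatter), so a much longer chain is expected to move in the same direction, with a fair chance that only a limit is reached. The expected step is a 2.2-fold higher number from compound 2 to compound 4 (0.35 log units; beyond the scatter). Compound 4 is therefore estimated at 200 mg/kg, within 80 mg/kg to 600 mg/kg.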

Compound 4, dose for half-maximal effect: > 100 mg/kg
Compound 4 was reported as a limit; the forecaster's own chance of this, stated with the estimate: 60%; the middle value does not contradict the limit.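

Placing decyl on this saturated chain carbon, five bonds along the chain from a carbonyl carbon, gives an at least 1.1-fold higher number from compound 2 to compound 4 (0.04 log units; that floor lies within the scatter), so this step cannot separate the two compounds. In this assay compound 4 gives only a limit, > 100 mg/kg. What is new is that a much longer chain, like the 4-phenylpiperazin-1-yl group of compound 3, yields no plain number: the limit of > 100 mg/kg in this assay, at which 2 of the 4 values shown sit.

On these data alone, it remains open whether an octyl chain would still give a plain number in this assay. As far as these compounds go, it also remains open how a carboxylic acid in place of the amino group of compound 1 would read.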